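The compounds below may be only part of what the source reports. "The series", "measured", "known", "first", "only" and "open" are said of these compounds alone.

Compound 2 `Cc1cc(Cl)nc(NC(=S)NC(=O)c2c(-c3ccc(Cl)cc3Cl)noc2C)n1` gives in a functional assay on the whole organism for inhibition, with Digitaria ciliaris as the target, with a stated time of 72 h, tested at 100 mg/L (a higher number here means more inhibition of growth at the concentration tested, a lower number less inhibition of growth), 44.2%, the lowest of the two numbers recorded; compound 1 `COc1cc(C)nc(NC(=S)NC(=O)c2c(-c3ccc(Cl)cc3Cl)noc2C)n1` stands nearest with 60.2%. Among the measured compounds shown here, the one measured step at this position, a number 16 percentage points lower from compound 1 to compound 2 (beyond the scatter), shows chloro lying below methoxy. Compound 3 `Cc1cc(C)nc(NC(=S)NC(=O)c2c(-c3ccc(Cl)cc3Cl)noc2C)n1` carries methyl in place of chloro on an aromatic carbon at that same carbon. For the measured compounds named here, no measured step shows methyl entering there, so the only guidance is that chloro gave the weaker number; a small rise back toward compound 1 is expected, as a number 7.8 percentage points higher from compound 2 to compound 3 (within the scatter), with wide uncertainty. For compound 3 the estimate in this assay is 52%, between 35% and 70%.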

Compound 3, percent growth inhibition at one concentration: 61.4%
For compound 3 the middle estimate is 9.4 percentage points below the measured one, within the range that was stated.
By their numbers in this assay, from the lowest: compound 2; then compounds 1 and 3 (each within the scatter of the next).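

In this assay, a number 17.2 percentage points higher from compound 2 to compound 3 (beyond the scatter) sets methyl at this carbon clear of chloro, while a number 1.2 percentage points higher from compound 1 to compound 3 (within the scatter) leaves methyl and methoxy indistinguishable. Of the three groups tested at this carbon, only chloro stands apart, and the methyl result shows that the lower number in compound 2 belongs to chloro rather than to the loss of methoxy alone. Going by these compounds, whether an amine or a longer chain such as ethoxy at this carbon would sit with methyl and methoxy or with chloro remains open. Nothing shown here offers a reason for the gap between chloro and the other two groups.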